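This account rests on a few compounds, and the source may have more. Where it says the series, first, only, none or still open, it means among the compounds named here.

Compounds measured so far:
compound 1 `O=C1C[C@H](OCc2cn(-c3ccc([N+](=O)[O-])cc3)nn2)[C@H]2CO[C@@H]1O2` — 10300 nM
compound 2 `O=C1C[C@H](OCc2cn(-c3ccc(Cl)cc3)nn2)[C@H]2CO[C@@H]1O2` — 10600 nM

In a functional assay on NCI-H1299 cells (Homo sapiens) for cytotoxicity, read by MTT assay, with a stated time of 48 h (a higher number here means a weaker inhibitor, a lower number a stronger inhibitor), compound 1 gives 10300 nM, and in this assay compound 2 gives 10600 nM. Compound 2 carries the higher of the two numbers, with compound 1 its nearest neighbour, but the step of a 1.0-fold higher number from compound 1 to compound 2 (0.01 log units; within the scatter) lies within the scatter, so the two cannot be told apart.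

Compound 3 `O=C1C[C@H](OCc2cn(-c3ccccc3)nn2)[C@H]2CO[C@@H]1O2` differs from compound 2 by hydrogen in place of chloro on an aromatic carbon. Within the data shown here, the only measured step that touches this aromatic carbon is a 1.0-fold higher number from compound 1 to compound 2 (0.01 log units; within the scatter), an exchange of one group for another at the same place that changed nothing beyond the scatter. On that basis compound 3 is expected to sit close to compound 2, with the step of a 1.0-fold higher number from compound 2 to compound 3 (0.02 log units; within the scatter) foreseen as no change beyond the scatter. The estimate for compound 3 in this assay is 11000 nM, within a range of 5000 nM to 25000 nM.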

Compound 3, half-maximal inhibitory concentration: 10900 nM
Estimate against measurement, compound 3: 1.0-fold (0.00 log units) above, within the range that was stated.
By their numbers in this assay, from the lowest: compounds 1, 2 and 3 (each within the scatter of the next).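

In this assay the change from 4-chlorophenyl to phenyl gives a 1.0-fold higher number from compound 2 to compound 3 (0.01 log units; within the scatter) and so counts as no change at this place on the six-membered aromatic ring. Hydrogen in place of nitro gives a 1.1-fold higher number from compound 1 to compound 3 (0.02 log units; within the scatter) and likewise stays within the scatter, so the compound with no substituent here cannot be told apart from either substituted compound, and among these three compounds the group at this place does not set the number. Nothing available explains why these three compounds read alike. From the compounds shown here alone, whether an amine, a carboxylic acid or a longer chain at this same place would shift the number remains open. So does whether a change elsewhere, such as at the carbonyl of the shared core, would move it.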